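Replacing an amino alcohol chain with a second aryl arm

The source may hold more compounds than are shown below. What is called first, only, known or untested is meant among the compounds shown, and "the series" means these compounds.

Compound 1 `CC(C)c1n[nH]c2c(NCc3ccc(-c4ccccn4)cc3)nc(N[C@@H]3CCCC[C@H]3N)nc12`, a functional assay on HCT-116 cells (Homo sapiens) for cytotoxicity, read by fluorescence, with a stated time of 72 h; a higher number here means a weaker inhibitor, a lower number a stronger inhibitor: 427 nM
Compound 2 `CC(C)c1n[nH]c2c(NCc3ccc(-c4ccccn4)cc3)nc(NCC(N)CO)nc12`, this assay: 781 nM
Compound 3 `CC(C)c1n[nH]c2c(NCc3ccc(-c4ccccn4)cc3)nc(N[C@H]3CC[C@H](N)CC3)nc12`, this assay: 720 nM

Compound 2 has the highest of the three numbers, yet the steps of a 1.8-fold higher number from compound 1 to compound 2 (0.26 log units; within the scatter) and a 1.1-fold lower number from compound 2 to compound 3 (0.04 log units; within the scatter) both sit within the scatter, so the three compounds stand together. Compound 4 `CC(C)c1n[nH]c2c(NCc3ccc(-c4ccccn4)cc3)nc(NCc3ccc(-c4ccccn4)cc3)nc12` differs from compound 2 in one place: 4-(pyridin-2-yl)phenyl in place of 1-amino-2-hydroxyethyl on a saturated chain carbon bound to a nitrogen on an aromatic ring. Among the compounds with values here, no measured step matches this change; every swap so far kept an amine-bearing group, and a 1.7-fold higher number from compound 1 to compound 3 (0.23 log units; within the scatter) also stayed within the scatter. Within the data shown here, with no close precedent, only a modest rise in the number is expected for compound 4, and this is the step of a 1.9-fold higher number from compound 2 to compound 4 (0.28 log units; within the scatter) that the estimate means. Compound 4 is therefore estimated at 1500 nM, with a wide range from 400 nM to 6000 nM.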

Compound 4, half-maximal inhibitory concentration: 7330 nM
The estimate for compound 4 lay 4.9-fold (0.69 log units) below the measured number, and the stated range ends below it.
By their numbers in this assay, from the lowest: compounds 1, 3 and 2 (each within the scatter of the next); then compound 4.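

Within the data shown here, at this position, on a saturated chain carbon bound to a nitrogen on an aromatic ring, this assay shows a 9.4-fold higher number from compound 2 to compound 4 (0.97 log units; beyond the scatter), the first step beyond the scatter. Among these compounds, the earlier swaps all kept an amine-bearing group, so this is the first sign that the position responds to a change, here from 1-amino-2-hydroxyethyl to 4-(pyridin-2-yl)phenyl. No evidence is available on what lies behind this step.

Going by these compounds, removing the amine and hydroxyl and adding the larger two-ring arm happen in one change, so their separate contributions remain open. A plain phenyl or a methyl at this place could help tell them apart.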